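The source may report more compounds than this note shows. Statements on the series, on what has been measured and on what is new or still open speak of the compounds shown alone.

Among the three compounds measured so far, compound 3 `CN1CCN(c2ccc(Nc3ncc4nc(Nc5ccc(F)cc5)n([C@H]5CCCN(S(=O)(=O)C6CC6)C5)c4n3)cc2)CC1` gives the lowest number: in a functional assay on HCC827 cells (Homo sapiens) for antiproliferative activity, read by MTT assay, with a stated time of 72 h (on this read-out lower numbers stand for stronger inhibition and higher numbers for weaker inhibition), compound 3 gives 8.6 nM. Compound 1 `CN1CCN(c2ccc(Nc3ncc4nc(Nc5ccccc5)n([C@H]5CCN(S(C)(=O)=O)C5)c4n3)cc2)CC1` gives 17 nM, a value within the usual scatter of compound 3, and compound 2 `CN1CCN(c2ccc(Nc3ncc4nc(Nc5ccccc5)n([C@H]5CCNC5)c4n3)cc2)CC1` gives 530 nM, a value well beyond it. Compound 4 `CN1CCN(c2ccc(Nc3ncc4nc(Nc5ccc(F)cc5)n([C@@H]5CCNC5)c4n3)cc2)CC1` has not yet been measured. It differs from compound 3 in one place: pyrrolidin-3-yl in place of 1-(cyclopropylsulfonyl)piperidin-3-yl on an aromatic nitrogen. Within the data shown here, only one measured step speaks to this kind of change. When the methylsulfonyl group on the amine nitrogen in a ring is replaced by hydrogen, the result is a 31-fold higher number from compound 1 to compound 2 (1.49 log units; beyond the scatter), a large loss. Compound 4 likewise loses its sulfonyl group and, with it, the cyclopropyl attached to that sulfur, while the ring on the aromatic nitrogen changes as described. A step of comparable size in the same direction is therefore expected, namely a 30-fold higher number from compound 3 to compound 4 (1.48 log units; beyond the scatter). Compound 4 is accordingly estimated to give 260 nM, with a plausible range from 80 nM to 850 nM.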

Compound 4, half-maximal inhibitory concentration: 300 nM
For compound 4 the middle estimate is 1.2-fold (0.06 log units) below the measured one; the measured number falls inside the stated range.
By their numbers in this assay, from the lowest: compounds 3 and 1 (each within the scatter of the next); then compounds 4 and 2 (each within the scatter of the next).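

Replacing 1-(cyclopropylsulfonyl)piperidin-3-yl with pyrrolidin-3-yl on the aromatic nitrogen gives a 35-fold higher number from compound 3 to compound 4 (1.54 log units; beyond the scatter) as a second large loss, this time in a compound carrying a (4-fluorophenyl)amino group. In both pairs shown, the compound with a sulfonyl group on the ring nitrogen gives the lower number, and neither pair goes against this, although this new step also changes the ring and removes the cyclopropyl group, so the separate contribution of each change cannot be read. Nothing available explains why the number rises at this position.

The compounds shown leave open how much of this step comes from losing the sulfonyl group and how much from the smaller ring. They also leave open whether an acetyl group on the ring nitrogen would give a number closer to that of compound 3 or compound 4.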